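This account rests on a few compounds, and the source may have more. Where it says the series, first, only, none or still open, it means among the compounds named here.

Two measured compounds open this series. Compound 1 `Nc1nn(C(=O)Nc2ccc(Cc3ccccc3)cc2)c2ccccc12` was tested in a functional assay on DU-145 cells (Homo sapiens) for antiproliferative activity, read by sulforhodamine B assay, with a stated time of 48 h (a lower number here means a stronger inhibitor of growth, a higher number a weaker inhibitor of growth), and gave 28300 nM. Compound 2 `Nc1nn(C(=O)Nc2ccc(Cc3ccccc3)cc2)c2ccc(Cl)cc12` adds a chloro in place of hydrogen on an aromatic carbon, and in this assay compound 2 gave 28900 nM. The step of a 1.0-fold higher number from compound 1 to compound 2 (0.01 log units; within the scatter) means the two numbers cannot be told apart. Going by the values given here, compound 2 therefore holds the highest of the two numbers known so far, but its nearest neighbour, compound 1, lies so close that no order between them can be claimed.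

The next compound, compound 3 `Nc1ccc2c(c1)c(N)nn2C(=O)Nc1ccc(Cc2ccccc2)cc1`, differs from compound 2 at that same place: amino in place of chloro on an aromatic carbon. Among the compounds with values here, only one measured step touches this position, the exchange of hydrogen for chloro from compound 1 to compound 2, and it stayed within the scatter. On that basis the expectation for the step of a 1.0-fold higher number from compound 2 to compound 3 (0.02 log units; within the scatter) is no movement beyond the scatter in either direction. Compound 3 is therefore estimated at 30000 nM in this assay, with a range from 12000 nM to 75000 nM.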

Compound 3, concentration for total growth inhibition: 24000 nM
Beside the measured number, compound 3's estimate is 1.3-fold (0.10 log units) above it; the measured number falls inside the stated range.
By their numbers in this assay, from the lowest: compounds 3, 1 and 2 (each within the scatter of the next).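

Swapping chloro for amino puts a hydrogen-bond donor and a hydrogen-bond acceptor where the chlorine stood, on the six-membered aromatic ring, yet in this assay the result is a 1.2-fold lower number from compound 2 to compound 3 (0.08 log units; within the scatter) and no real difference can be claimed. Set against the unsubstituted compound, the picture is the same, with a 1.2-fold lower number from compound 1 to compound 3 (0.07 log units; within the scatter), so hydrogen, chloro and amino at this place cannot be told apart in this assay, whereas the earlier compounds had only compared hydrogen with chloro. Nothing available explains why such different groups give numbers this close, so the result is a plain observation about these three compounds and no more.

From the compounds shown here alone, whether any group at this position can move the number beyond the scatter remains open, and a carboxylic acid, a methoxy group or a longer chain would be informative tests, since each differs from the three groups seen so far. Also open, going by these compounds, is whether the same groups would behave alike at another position on this ring, as all three compounds vary at this one place only.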